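Cytotoxicity notes on compounds 1 to 3

The compounds below may be only part of what the source reports. "The series", "measured", "known", "first", "only" and "open" are said of these compounds alone.

Measured so far:
compound 1 `COc1ccc(-n2c(=O)n(Cc3cc4cc(Cl)ccc4n3CCCC#N)c3cnccc32)c(F)c1`: in an ADME assay on HeLa cells (Homo sapiens) for cytotoxicity, read by ATP content, with a stated time of 3 days (a higher number here means that more compound is tolerated, a lower number that less compound is tolerated), compound 1 gives > 50000 nM, which is a limit of the assay and not a number.
compound 2 `O=C(O)CCCn1c(Cn2c(=O)n(C3CC3)c3ccncc32)cc2cc(Cl)ccc21`: in this assay compound 2 gives > 50000 nM, also a limit of the assay.

Compound 2 therefore stands at the upper bound of what the assay reports, and it is not alone there: the limit of > 50000 nM in this assay, at which 2 of the 2 values shown sit. Among the measured compounds shown here, neither measured value gives a number to compare, so no step between measured compounds can be drawn from these two.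

Compound 3 `N=C(CCCn1c(Cn2c(=O)n(C3CC3)c3ccncc32)cc2cc(Cl)ccc21)NO` differs from compound 2 as follows: a group of 4 heavy atoms (1 carbon, 2 nitrogen, 1 oxygen; no ring) in place of a group of 3 heavy atoms (1 carbon, 2 oxygen; no ring), on a saturated chain carbon, three bonds along the chain from an aromatic nitrogen.

For the measured compounds named here, with both values at a limit, the step from carboxy to the entering group gives no measured precedent. The expectation is that the step of a number no higher from compound 2 to compound 3 (the limit leaves the size open) stays within the scatter, with compound 3 most likely again reported as a limit. Compound 3 is estimated at 50000 nM in this assay, with an expected range from 20000 nM to 100000 nM.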

Compound 3, half-maximal cytotoxic concentration: > 50000 nM
Compound 3 gave a limit, no number; the forecaster's own chance of this, stated with the estimate: 75%; the middle value lies on the limit itself.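

In this assay no step can be read between compound 2 and compound 3, each being reported only as a limit of the assay: the limit of > 50000 nM in this assay, at which 3 of the 3 values shown sit.

The compounds shown leave open at what concentration any of them becomes cytotoxic, and whether replacing carboxy alters that concentration at all.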